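Extending a Furan Amide Linker at an Alpha-1 Antagonist

The source may report more compounds than this note shows. Statements on the series, on what has been measured and on what is new or still open speak of the compounds shown alone.

Measured so far:
compound 1 `COc1cc2nc(NCCCNC(=O)c3ccco3)nc(N)c2cc1OC`, 9.77 nM
compound 2 `COc1cc2nc(NCCCCNC(=O)c3ccco3)nc(N)c2cc1OC`, 5.62 nM

Both numbers come from a functional assay for antagonist activity at Adrenergic receptor alpha-1 (Rattus norvegicus); a higher number here means weaker binding, a lower number tighter binding. Compound 2 sits close to compound 1 in this assay: a 1.7-fold lower number from compound 1 to compound 2 (0.24 log units; within the scatter). Compound 3 `COc1cc2nc(NCCCCCCNC(=O)c3ccco3)nc(N)c2cc1OC` is not yet measured; it differs from compound 2 in that (2-(((furan-2-yl)carbonyl)amino)ethyl in place of ((furan-2-yl)carbonyl)amino on a saturated chain carbon, four bonds along the chain from a nitrogen on an aromatic ring). Among the compounds with values here, the only step that bears on this further lengthening of the chain is a 1.7-fold lower number from compound 1 to compound 2 (0.24 log units; within the scatter), a small change within the scatter, so no step beyond the scatter is expected here, in either direction. Compound 3 is therefore estimated at 5 nM, with a range from 2 nM to 15 nM. The expected step of a 1.1-fold lower number from compound 2 to compound 3 (0.05 log units; within the scatter) lies within the scatter.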

Compound 3, dissociation constant: 13.2 nM
Compound 3: middle estimate off by 2.6-fold (0.42 log units), on the low side, and the stated range covers the measured number.
By their numbers in this assay, from the lowest: compounds 2, 1 and 3 (each within the scatter of the next, the first and the last beyond it).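

Adding to the chain at this position now has a measurable cost: the step from the ((furan-2-yl)carbonyl)amino chain end to the longer 2-(((furan-2-yl)carbonyl)amino)ethyl form (a 2.3-fold higher number from compound 2 to compound 3 (0.37 log units; beyond the scatter)) is a modest move towards weaker binding. Within the data shown here, the earlier lengthening (a 1.7-fold lower number from compound 1 to compound 2 (0.24 log units; within the scatter)) stayed within the scatter, so only this step shows that chain length can matter here. No available evidence explains the change. As far as these compounds go, whether a still longer chain would weaken binding further remains open. So does the effect of replacing the furan ring with an amine or a carboxylic acid.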